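A few compounds are considered here, and "the series" means these few. Any claim that something is new, unique, unknown or untested is made for them only; others in the source may bear on it.

Compounds measured in an assay on isolated protein for binding affinity to leukotriene B4 receptor 1 (Homo sapiens), tested at 1 uM; a lower number here means less inhibition, a higher number more inhibition at the concentration tested (going by the name of the read-out):
compound 1 `CCCCCc1cc(C(C)=O)c(O)cc1OCCCCC#N`: 14%
compound 2 `CC(=O)c1cc(CC(C)O)c(OCCCCC#N)cc1O`: 6%
compound 3 `CC(=O)c1cc(C=O)c(OCCCCC#N)cc1O`: 3%

Compound 3 holds the lowest of the three numbers, but the gap to compound 2, a number 3 percentage points lower from compound 2 to compound 3 (within the scatter), is within the scatter, and only the gap to compound 1, a number 11 percentage points lower from compound 1 to compound 3 (beyond the scatter), is a modest step beyond it. Compound 4 `CC(=O)c1cc(C(C)=O)c(OCCCCC#N)cc1O` differs from compound 3 by methyl in place of hydrogen on a carbonyl carbon. Among the compounds with values here, no measured step alters a carbonyl carbon; the steps that touch the same aromatic carbon were small or modest, and all three numbers sit low. For compound 4 no step beyond the scatter is therefore expected, a number 2 percentage points higher from compound 3 to compound 4 (within the scatter). The estimate for compound 4 in this assay is 5%, ranging from -4% to 15%.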

Compound 4, a percentage reported as inhibition, at one concentration (the size of the read-out at that concentration, not a potency): 0%
Compound 4: middle estimate off by 5 percentage points, on the high side, and the stated range covers the measured number.
By their numbers in this assay, from the lowest: compounds 4, 3, 2 and 1 (each within the scatter of the next, the first and the last beyond it).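

In this assay, the change from formyl to acetyl, the first on a carbonyl carbon, gives a number 3 percentage points lower from compound 3 to compound 4 (within the scatter), so this added methyl shifts the number by no more than the scatter. On the aromatic carbon, acetyl in place of 2-hydroxypropyl gives a number 6 percentage points lower from compound 2 to compound 4 (within the scatter), whereas acetyl in place of pentyl gives a number 14 percentage points lower from compound 1 to compound 4 (beyond the scatter), a modest step that matches the one seen with formyl. Nothing shown gives a reason for these numbers.

As far as these compounds go, whether an amine or a carboxylic acid on this carbonyl carbon would lift the number remains open. With every number low at a single concentration, no potency can be read.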